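The source may report more compounds than this note shows. Statements on the series, on what has been measured and on what is new or still open speak of the compounds shown alone.

Compound 1, `Cc1ccsc1/C=C(/SCc1ccc(Cl)cc1)C(=O)c1ccc(Cl)cc1`, and compound 2, `Cc1ccc(S/C(=C/c2sccc2C)C(=O)c2ccc(Cl)cc2)cc1`, share a core and differ by 4-methylphenyl in place of 4-chlorobenzyl on a sulfur. In a functional assay on DU-145 cells (Homo sapiens) for inhibition, read by trypan blue exclusion, with a stated time of 96 h (a lower number here means a stronger inhibitor of growth, a higher number a weaker inhibitor of growth), compound 1 gives 50000 nM, and compound 2 gives 50000 nM, so the step of no change at the digits printed from compound 1 to compound 2 (within the scatter). Compound 3, `COc1cc(OC)c(/C=C(\C(=O)c2ccc(Br)cc2)S(=O)(=O)Cc2ccc(Cl)cc2)c(OC)c1`, is built on a different core; the difference between the two cores is not broken down here. In this assay compound 3 gives 25000 nM. Compound 4, `COc1cc(OC)c(/C=C(\C(=O)c2ccc(Br)cc2)S(=O)(=O)c2ccc(C)cc2)c(OC)c1`, differs from compound 3 by 4-methylphenyl in place of 4-chlorobenzyl on a sulfonyl sulfur. Around the place, the sulfur carries a sulfonyl group in compound 3, while in compound 1 it is a bare sulfur, so this is the same kind of change rather than the same one. The step is expected to be about no change at the digits printed from compound 3 to compound 4 (within the scatter), because no change at the digits printed from compound 1 to compound 2 (within the scatter). Compound 4 is estimated at 25000 nM, between 10000 nM and 60000 nM.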

Compound 4, concentration for 50% growth inhibition: > 100000 nM
Compound 4 ended at the assay's limit; the forecaster's own chance of this, stated with the estimate: 30%; middle value at least 4.0-fold (0.60 log units) from the limit.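

In this assay, 4-methylphenyl in place of 4-chlorobenzyl on a sulfonyl sulfur gives an at least 4.0-fold higher number from compound 3 to compound 4 (0.60 log units; beyond the scatter), so the change did not carry over unaltered from the pair on the other core: the same change on two cores in this assay, no change at the digits printed (within the scatter) from compound 1 to compound 2 and an at least 4.0-fold higher number (0.60 log units; beyond the scatter) from compound 3 to compound 4, at least 4.0-fold (0.60 log units) apart, beyond the scatter of two such steps

Compound 4 stands at a limit of the assay, > 100000 nM, which is not a number, so the full size of its step stays unknown: the limit of > 100000 nM in this assay, at which 1 of the 4 values shown sits.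

The two cores differ in more than the sulfonyl group, and these two pairs do not show which difference separates the steps.

Open, on these data alone, is whether the same change would behave alike with a sulfonyl group on the core of compound 1, or with a bare sulfur on the core of compound 3. Also open, as far as these compounds go, is how an amine or a carboxylic acid would read at this place.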